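Hydroxy to ethylamino on the amide side chain

The source may report more compounds than this note shows. Statements on the series, on what has been measured and on what is new or still open speak of the compounds shown alone.

Values in a functional assay on HeLa cells (Homo sapiens) for antiproliferative activity, read by MTT assay, with a stated time of 48 h (a higher number here means a weaker inhibitor, a lower number a stronger inhibitor), for the compounds measured so far:
- compound 1 (`C=C(c1ccc2c(c1)C=CC(C)(C)O2)c1ccc(OC)cc1NC(=O)CO`): 100 nM
- compound 2 (`C=C(c1ccc(OC)cc1NC(=O)CNC)c1ccc(OC)c2c1C=CC(C)(C)O2`): 500 nM

Compound 1 holds the lower number of the two, and its gap to compound 2 lies beyond the scatter. Compound 3 (`C=C(c1ccc2c(c1)C=CC(C)(C)O2)c1ccc(OC)cc1NC(=O)CNCC`) keeps the core of compound 1 and has ethylamino in place of hydroxy on a saturated chain carbon bound to a carbonyl carbon. Among the compounds with values here, no measured pair isolates this change. Compound 2 also has a nitrogen on that chain, but differs from compound 1 elsewhere too, so the value of compound 2 (500 nM) is only a loose guide. In this assay a moderate step to a higher number, beyond the scatter, is expected. The estimated change is a 3.0-fold higher number from compound 1 to compound 3 (0.48 log units; beyond the scatter) in that direction. For compound 3 the expected value is 300 nM (estimated range 90 nM to 1000 nM).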

Compound 3, half-maximal inhibitory concentration: 1580 nM
Compound 3: middle estimate off by 5.3-fold (0.72 log units), on the low side, outside the stated range (above it).
By their numbers in this assay, from the lowest: compound 1; then compound 2; then compound 3.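

Within the data shown here, the change from hydroxy to ethylamino on a saturated chain carbon bound to a carbonyl carbon gives the first single-place reading at this position in this assay, and a 16-fold higher number from compound 1 to compound 3 (1.20 log units; beyond the scatter) marks it as a large weakening on the unchanged core of compound 1. The position is therefore sensitive to this exchange, even though the entering and leaving groups match in hydrogen-bond donor and acceptor counts and carry no net charge, and the group grows from 1 heavy atom to 3. Nothing measured here bears on the cause of the step.

Still open, from the compounds shown here alone, is how much of the step belongs to the exchange of oxygen for nitrogen and how much to the ethyl part. An unsubstituted amino group or a methoxy group at this place on the core of compound 1 would help separate the two.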